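The source may hold more compounds than are shown below. What is called first, only, known or untested is meant among the compounds shown, and "the series" means these compounds.

In an ADME assay on HEK293 cells (Homo sapiens) for cytotoxicity, with a stated time of 72 h (a higher number here means that more compound is needed for the effect, a lower number that less compound is needed), compound 1 `C=C[C@@](C)(/C=C/c1ccc(O)c(/C=C/C(=O)c2ccccc2)c1)CCC=C(C)C` gives > 7410 nM, which is a limit and not a number. Compound 2 `C=C[C@@](C)(/C=C/c1ccc(O)c(/C=C/c2ccc(F)cc2)c1)CCC=C(C)C` gives > 36600 nM, which is also a limit. Both values shown are therefore limits, and compound 1 has no exact number from which to start. Compound 3 `COc1ccc(/C=C/[C@@](C)(/C=C/c2ccc(O)c(/C=C/C(=O)c3ccccc3)c2)CCC=C(C)C)cc1` differs from compound 1 in one place: 2-(4-methoxyphenyl)ethenyl in place of vinyl on a saturated chain carbon bound to a double-bonded chain carbon and two saturated chain carbons. A 2-(4-methoxyphenyl)ethenyl group thus replaces the vinyl group on the saturated chain carbon. Among the compounds with values here, the only measured step, a step that the two limits leave unreadable from compound 1 to compound 2, changes a different place in the structure and gives no size to carry over. No firm direction can be drawn from it, and a limit is again a likely result. The estimated step is a step that the limit leaves unreadable from compound 1 to compound 3, an expectation that remains loose. For compound 3 the expected value is 12000 nM, with an estimated range from 3000 nM to 45000 nM.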

Compound 3, half-maximal effective concentration: > 36600 nM
Compound 3 ended at the assay's limit (the forecaster's own chance of this, stated with the estimate: 60%); at least 3.0-fold (0.48 log units) between middle value and limit.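

Compound 3, like compound 1 and compound 2, sits at a limit in this assay, so the steps linking these compounds cannot be read. What the compounds shown leave open is how much compound any of them needs for the effect, and whether either replacement changes that.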